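Adding a (difluoromethyl)sulfanyl group to a cytotoxicity-limit compound

A few compounds are considered here, and "the series" means these few. Any claim that something is new, unique, unknown or untested is made for them only; others in the source may bear on it.

The account concerns a toxicity assay on MDCK cells (Canis lupus familiaris) for cytotoxicity, read by crystal violet staining, with a stated time of 48 h (on this read-out lower numbers stand for higher toxicity in this test and higher numbers for lower toxicity in this test), and two compounds carrying the shared core. Compound 1 `Cc1ccc2[nH]c(=O)c(CN(Cc3ccccc3)Cc3ccc(C(C)(C)C)cc3)cc2c1` has in this assay only a limit, > 5000 nM; that is where it stands, at the limit of > 5000 nM in this assay, at which 1 of the 2 values shown sits. Compound 2 `Cc1ccc2cc(CN(Cc3ccc(C(C)(C)C)cc3)C3CCCC3)c(=O)[nH]c2c1` likewise has only a limit in this assay, > 10000 nM, sitting at the limit of > 10000 nM in this assay, at which 1 of the 2 values shown sits. Among the compounds with values here, no pair of these measured compounds differs in a single place, so no measured step can be stated; the two values show only that neither reached a measurable half-maximal cytotoxic concentration within its tested range.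

Compound 3 `Cc1ccc2[nH]c(=O)c(CN(Cc3ccc(SC(F)F)cc3)Cc3ccc(C(C)(C)C)cc3)cc2c1` is not yet measured in this assay. It differs from compound 1 by (difluoromethyl)sulfanyl in place of hydrogen on an aromatic carbon. With compound 1 standing at a limit, the step from compound 1 to compound 3 is expected to be none beyond the scatter, a change of roughly a step that the limit leaves unreadable from compound 1 to compound 3. Compound 3 is estimated in this assay at 10000 nM, with a range from 3000 nM to 30000 nM, and most likely the assay will again report only a limit.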

Compound 3, half-maximal cytotoxic concentration: > 5000 nM
Compound 3: a limit, no number; the forecaster's own chance of this, stated with the estimate: 70%; the middle value does not contradict the limit.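

In this assay compound 3 gives > 5000 nM, which is a limit and not a number. Within the data shown here, compound 1 also has only a limit in this test, and no step from compound 1 to compound 3 can be read. The compounds shown leave open whether (difluoromethyl)sulfanyl in place of hydrogen changes the half-maximal cytotoxic concentration at all.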